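Aryl Variation on the Shared Core: Antiproliferative Notes

A few compounds are considered here, and "the series" means these few. Any claim that something is new, unique, unknown or untested is made for them only; others in the source may bear on it.

Measured so far:
compound 1, `CCOc1ccc(-c2ccc3ncn(-c4cc(OC)c(OC)c(OC)c4)c3c2)cc1`, 2970 nM in a functional assay on SGC-7901 cells (Homo sapiens) for antiproliferative activity, read by MTT assay, with a stated time of 72 h; a higher number here means a weaker inhibitor, a lower number a stronger inhibitor
compound 2, `COc1cc(-n2cnc3ccc(-c4ccc(C)cc4F)cc32)cc(OC)c1OC`, 5650 nM in this assay

Among the measured compounds shown here, compound 2 stands as one of only two measured numbers, and the step of a 1.9-fold higher number from compound 1 to compound 2 (0.28 log units; within the scatter) places it within the scatter of compound 1, so the two cannot be separated on present data. For the measured compounds named here, the single measured step concerns the same aryl group on the same aromatic carbon of the shared core, and it is small.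

Compound 3, `COc1cc(-n2cnc3ccc(-c4ccccc4)cc32)cc(OC)c1OC`, is not yet measured. The change phenyl in place of 2-fluoro-4-methylphenyl on an aromatic carbon again alters only the aryl group at that position. Going by the values given here, the one comparable step, a 1.9-fold higher number from compound 1 to compound 2 (0.28 log units; within the scatter), lies within the scatter, so no step beyond the scatter is expected in either direction for this assay here; the smaller phenyl may remove the slight excess seen in compound 2, but that excess is itself within noise.

Compound 3 is therefore expected to give about 4000 nM in this assay, with a likely range of 1500 nM to 11000 nM, which means an estimated step of a 1.4-fold lower number from compound 2 to compound 3 (0.15 log units; within the scatter).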

Compound 3, half-maximal inhibitory concentration: 290 nM
For compound 3 the middle estimate is 14-fold (1.14 log units) above the measured one; measured number below the stated range.
By their numbers in this assay, from the lowest: compound 3; then compounds 1 and 2 (each within the scatter of the next).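

In this assay, among the compounds shown here, this position proves far more sensitive than the earlier pair suggested: phenyl in place of 2-fluoro-4-methylphenyl gives a 19-fold lower number from compound 2 to compound 3 (1.29 log units; beyond the scatter), and hydrogen in place of ethoxy gives a 10-fold lower number from compound 1 to compound 3 (1.01 log units; beyond the scatter), whereas the only earlier step lay within the scatter. Among these three compounds, the unsubstituted phenyl of compound 3 therefore gives the lowest number, with both steps to it beyond the scatter, while the ethoxy-bearing and fluoro-methyl-bearing aryl groups of compound 1 and compound 2 cannot be separated from each other, although they carry quite different substituents. Nothing available here accounts for the size of these steps.

Compound 2 carries its fluorine and methyl together, so the compounds shown do not tell whether either one alone, as in a phenyl bearing only a fluorine or only a methyl, would keep the number of compound 3 or raise it to that of compound 2. Also open, as far as these compounds go, is whether any substituent on this phenyl is compatible with a low number, for instance a smaller methoxy, a hydroxyl, an amine or a carboxylic acid.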